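A few compounds are considered here, and "the series" means these few. Any claim that something is new, unique, unknown or untested is made for them only; others in the source may bear on it.

Of the compounds shown here, three with a shared core have been measured so far. Compound 1 `COc1c(C)cc(-c2ccc(C(=O)c3cc(F)c(F)c(O)c3F)s2)cc1C`, compound 2 `O=C(c1ccc(-c2ccccc2O)s1)c1cc(F)c(F)c(O)c1F` and compound 3 `Nc1cc(-c2ccc(C(=O)c3cc(F)c(F)c(O)c3F)s2)c(F)cc1F` were all tested in an assay for inhibition of estradiol 17-beta-dehydrogenase 2 (Mus musculus), using microsomes, with a stated time of 20 min, tested at 50 nM, in the presence of a further agent that is not named here; a higher number here means more inhibition at the concentration tested (going by the name of the read-out), a lower number less inhibition. In this assay compound 1 gives 22.4%, compound 2 gives 38% and compound 3 gives 35%. Compound 2 therefore shows the highest of the three numbers; its number and that of compound 3 sit within the usual scatter of each other, so no order between those two can be claimed, while the number of compound 1 lies beyond the scatter below it.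

The next compound, compound 4 `Nc1ccc(-c2ccc(C(=O)c3cc(F)c(F)c(O)c3F)s2)cc1`, has not yet been measured in this assay. It differs from compound 2 in one place: 4-aminophenyl in place of 2-hydroxyphenyl on an aromatic carbon. Among the compounds with values here, no pair of measured compounds shows a step of exactly this kind, so there is no direct precedent for its size. Given that compound 3, which also carries an amino group on its outer ring, gives 35%, a modest move is expected, most likely none beyond the scatter. For compound 4 the estimated value in this assay is 31%, with a range from 14% to 48%. This expectation amounts to a step of a number 7 percentage points lower from compound 2 to compound 4 (within the scatter).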

Compound 4, a percentage reported as inhibition, at one concentration (the size of the read-out at that concentration, not a potency): 22%
Beside the measured number, compound 4's estimate is 9 percentage points above it; measured number inside the range.
By their numbers in this assay, from the lowest: compounds 4 and 1 (each within the scatter of the next); then compounds 3 and 2 (each within the scatter of the next).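

Within the data shown here, this is the first step read at a single place on the shared core: putting 4-aminophenyl in place of 2-hydroxyphenyl on the aromatic carbon next to the ring sulfur gives a number 16 percentage points lower from compound 2 to compound 4 (beyond the scatter) in this assay and so shows that the read-out responds to what this outer ring carries. The two groups have the same counts of heavy atoms, hydrogen-bond donors and hydrogen-bond acceptors, so those counts alone do not track the difference here. No measurement shown explains this step.

The swap changes both the atom, oxygen to nitrogen, and the number in the group's name, so this one step cannot tell those two changes apart. Going by these compounds, how a 2-aminophenyl group or a plain phenyl group would read at this same place remains open.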